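From 2,6-dichlorophenyl to 2,6-difluorophenyl in compound 4

This account rests on a few compounds, and the source may have more. Where it says the series, first, only, none or still open, it means among the compounds named here.

In a functional assay on MT4 cells (Homo sapiens) for cytotoxicity (a lower number here means that less compound is tolerated, a higher number that more compound is tolerated), compound 2 `CCC(c1cc(O)nc(SC2CCCC2)n1)c1c(Cl)cccc1Cl` gives 70000 nM, level with compound 1 `CC(c1cc(O)nc(SC2CCCC2)n1)c1c(Cl)cccc1Cl` at 78300 nM, whereas compound 3 `CCC(c1cc(O)nc(SC2CCCCC2)n1)c1c(Cl)cccc1Cl` gives 200000 nM. Compound 4 `CCC(c1cc(O)nc(SC2CCCC2)n1)c1c(F)cccc1F` keeps everything in compound 2 except one group: 2,6-difluorophenyl in place of 2,6-dichlorophenyl on a saturated chain carbon bound to an aromatic carbon and a saturated chain carbon. Neither measured step touches that group. Adding a methyl on the chain gave a 1.1-fold lower number from compound 1 to compound 2 (0.05 log units; within the scatter), and cyclohexyl in place of cyclopentyl on the sulfur gave a 2.9-fold higher number from compound 2 to compound 3 (0.46 log units; beyond the scatter). The data therefore contain no direct guide to this swap, so no step beyond the scatter is expected in this assay. The estimated change is a 1.3-fold higher number from compound 2 to compound 4 (0.11 log units; within the scatter). For compound 4, the expected value is 90000 nM, within an estimated range of 35000 nM to 220000 nM.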

Compound 4, half-maximal cytotoxic concentration: > 200000 nM
Compound 4 was reported as a limit; the forecaster's own chance of this, stated with the estimate: 15%; at least 2.2-fold (0.34 log units) between middle value and limit.
By their numbers in this assay, from the lowest: compounds 2 and 1 (each within the scatter of the next); then compound 3.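

In this assay, going by these compounds alone, 2,6-difluorophenyl in place of 2,6-dichlorophenyl gives an at least 2.8-fold higher number from compound 2 to compound 4 (0.45 log units; beyond the scatter), so this place, untouched by the earlier steps, can move the tolerated concentration beyond the scatter. Compound 4 is reported only as a limit, so the full size of this step cannot be read: the limit of > 200000 nM in this assay, at which 1 of the 4 values shown sits.

The compounds shown leave open whether another group here, such as plain phenyl or 2,6-dimethylphenyl, would shift the number in the same direction. They also leave open whether 2,6-difluorophenyl would do the same with cyclohexyl on the sulfur.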